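The source may report more compounds than this note shows. Statements on the series, on what has been measured and on what is new or still open speak of the compounds shown alone.

Compound 1 `CCCCC/C=C/C=C/C=N/Nc1nc(N)c2ncn([C@@H]3O[C@H](CO)[C@@H](O)[C@H]3O)c2n1` gives 2 nM in an assay on CHO-K1 cells for displacement of a labelled ligand from adenosine receptor A1 (Homo sapiens), read by scintillation counting, with a stated time of 60 min; on this read-out higher numbers stand for weaker inhibition and lower numbers for stronger inhibition.
Compound 2 `Nc1nc(N/N=C/c2ccc(Br)cn2)nc2c1ncn2[C@@H]1O[C@H](CO)[C@@H](O)[C@H]1O` gives 4.7 nM in this assay.

For the measured compounds named here, of these two numbers, compound 2 stands highest; its only neighbour is compound 1, and the gap between them is the step of a 2.4-fold higher number from compound 1 to compound 2 (0.37 log units; beyond the scatter). Compound 3 `Nc1nc(N/N=C/c2ccc(-n3ccnc3)cc2)nc2c1ncn2[C@@H]1O[C@H](CO)[C@@H](O)[C@H]1O` carries a new group at the same place: 4-(1H-imidazol-1-yl)phenyl in place of 5-bromopyridin-2-yl on a carbon with a double bond to nitrogen. Going by the values given here, that one measured step is the only guide, and it concerns a different swap on the same carbon, so it bears on the new change only loosely. A step of similar, modest size is therefore expected, leaning toward a higher number, a 1.7-fold higher number from compound 2 to compound 3 (0.23 log units; within the scatter). Compound 3 is thus expected to give 8 nM, within 2.5 nM to 25 nM.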

Compound 3, inhibition constant: > 10000 nM
Compound 3: a limit, no number (the forecaster's own chance of this, stated with the estimate: 3%); middle value at least 1200-fold (3.09 log units) from the limit.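

Compound 3 has only a limit, not a number: the limit of > 10000 nM in this assay, at which 1 of the 3 values shown sits. Even so, the earlier modest step, a 2.4-fold higher number from compound 1 to compound 2 (0.37 log units; beyond the scatter), made this carbon look tolerant of quite different groups, and this result shows that it is not. The change to 4-(1H-imidazol-1-yl)phenyl gives an at least 2100-fold higher number from compound 2 to compound 3 (3.32 log units; beyond the scatter), and measured against the open chain it gives an at least 5000-fold higher number from compound 1 to compound 3 (3.69 log units; beyond the scatter).

On these data alone, what a plain phenyl group would give at this carbon remains open. The large step therefore cannot yet be assigned to the five-membered ring or to the six-membered ring of the new group.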